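Swapping a Fluorophenyl Sulfonate Ester for a Methylphenyl One

A few compounds are considered here, and "the series" means these few. Any claim that something is new, unique, unknown or untested is made for them only; others in the source may bear on it.

Compound 1 `O=C(O)CCCCCCC(=O)Nc1ccc(C2=C(c3ccc(O)cc3)C3CC(S(=O)(=O)Oc4ccc(F)cc4)C2O3)cc1` was tested in a functional assay on DU-145 cells (Homo sapiens) for inhibition, read by MTT assay, with a stated time of 72 h; a lower number here means a stronger inhibitor, a higher number a weaker inhibitor. For compound 1 only a limit was recorded, > 100000 nM, which marks the edge of what the assay reports rather than a number. Two relatives give numbers: compound 2 `O=C(O)CCCCCCC(=O)Nc1ccc(OS(=O)(=O)C2CC3OC2C(c2ccc(O)cc2)=C3c2ccc(O)cc2)cc1` gives 34800 nM, and compound 3 `O=C(CCCCCCC(=O)Nc1ccc(C2=C(c3ccc(O)cc3)C3CC(S(=O)(=O)Oc4ccc(Br)cc4)C2O3)cc1)NO` gives 11300 nM. Compound 4 `Cc1ccccc1OS(=O)(=O)C1CC2OC1C(c1ccc(NC(=O)CCCCCCC(=O)O)cc1)=C2c1ccc(O)cc1` has not yet been measured. It differs from compound 1 in one place: 2-methylphenyl in place of 4-fluorophenyl on an oxygen. Within the data shown here, no single-change step between measured compounds is available, so the weight of this swap cannot be read from neighbours. The expected step of a number no higher from compound 1 to compound 4 (the limit leaves the size open) is none beyond the scatter, because compound 1 sits at the limit of > 100000 nM in this assay, at which 1 of the 3 values shown sits. Compound 4 is estimated at 100000 nM, expected between 30000 nM and 300000 nM, and may itself come back as a limit.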

Compound 4, half-maximal inhibitory concentration: > 100000 nM
Compound 4 gave a limit, no number; the forecaster's own chance of this, stated with the estimate: 60%; the middle value lies on the limit itself.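

Compound 1 and compound 4 both end at a limit in this assay, so no step between them can be read: the limit of > 100000 nM in this assay, at which 2 of the 4 values shown sit.

The compounds shown leave open whether 2-methylphenyl in place of 4-fluorophenyl on an oxygen changes inhibition at all.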